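From Alkyl Ether to Ester on a Shared Core

The source may report more compounds than this note shows. Statements on the series, on what has been measured and on what is new or still open speak of the compounds shown alone.

Compound 1 `CCOc1ccc2oc(/C=C/[S+](C)[O-])cc(=O)c2c1` carries an ethoxy group on the shared core and, in a functional assay on A549 cells (Homo sapiens) for cytotoxicity, with a stated time of 48 h (a higher number here means a weaker inhibitor, a lower number a stronger inhibitor), compound 1 gives 1500 nM. Among the three measured compounds it has the highest number, though compound 2 `CC(C)COc1ccc2oc(/C=C/[S+](C)[O-])cc(=O)c2c1` with 1100 nM and compound 3 `CCCCOc1ccc2oc(/C=C/[S+](C)[O-])cc(=O)c2c1` with 1400 nM lie within the scatter of it: a 1.4-fold lower number from compound 1 to compound 2 (0.13 log units; within the scatter) and a 1.1-fold lower number from compound 1 to compound 3 (0.03 log units; within the scatter). Between those two, a 1.3-fold higher number from compound 2 to compound 3 (0.10 log units; within the scatter). Compound 4 `CC(C)C(=O)Oc1ccc2oc(/C=C/[S+](C)[O-])cc(=O)c2c1` differs from compound 1 by isopropylcarbonyl in place of ethyl on an oxygen on an aromatic ring. The measured steps only swap one alkyl chain for another on the oxygen, and all stayed within the scatter; none replaces the chain with an isopropylcarbonyl, so they bear on this step only loosely. The account therefore expects no step beyond the scatter, no change at the digits printed from compound 1 to compound 4 (within the scatter), and estimates compound 4 at 1500 nM with a range from 600 nM to 4000 nM.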

Compound 4, half-maximal inhibitory concentration: 2400 nM
The estimate for compound 4 lay 1.6-fold (0.20 log units) below the measured number; the range from low to high includes it.
By their numbers in this assay, from the lowest: compounds 2, 3, 1 and 4 (each within the scatter of the next, the first and the last beyond it).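

In this assay, going by these compounds alone, putting isopropylcarbonyl on the oxygen gives the first step at this position to pass the scatter, though only modestly and only against the isobutyl ether (a 2.2-fold higher number from compound 2 to compound 4 (0.34 log units; beyond the scatter)). Against the other two ethers, the ester stays within the scatter (a 1.6-fold higher number from compound 1 to compound 4 (0.20 log units; within the scatter); a 1.7-fold higher number from compound 3 to compound 4 (0.23 log units; within the scatter)). No evidence here explains that step. As far as these compounds go, it remains open whether a free hydroxyl, a carbamate or an acetyl group on this oxygen would separate more clearly from the alkyl ethers. From the compounds shown here alone, a longer acyl chain also remains untested against these values.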